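A few compounds are considered here, and "the series" means these few. Any claim that something is new, unique, unknown or untested is made for them only; others in the source may bear on it.

Compound 1 `CC(=O)OCCOn1cnc2c(Cl)nc(N)nc21`. In a functional assay on L1210 cells (Mus musculus) for inhibition (on this read-out higher numbers stand for weaker inhibition and lower numbers for stronger inhibition), compound 1 gives > 500000 nM, which is a limit of the assay rather than a number.
Compound 2 `CC(O)n1cnc2c(Cl)nc(I)nc21`. Compound 2 gives > 500000 nM, again a limit.
Compound 3 `CC(=O)OCCOn1cnc2c(S)nc(N)nc21`. Compound 3 gives 3200 nM.

Among the measured compounds shown here, compound 3 thus stands as the only compound with a measured number; the two other values sit at the limit described by the limit of > 500000 nM in this assay, at which 2 of the 3 values shown sit. For the measured compounds named here, the single measured step, an at least 150-fold lower number from compound 1 to compound 3 (2.19 log units; beyond the scatter), shows that exchanging chloro for sulfanyl turned a limit into a number.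

Compound 4 `CC(=O)OCCOn1cnc2c(S)nc(F)nc21` differs from compound 3 by fluoro in place of amino on an aromatic carbon. Going by the values given here, no measured step touches this position: the step from compound 1 to compound 3 changed a different group, and compound 2 shares no single-change pair with any other compound. The expectation therefore rests on little. The amino group leaves together with its donor and acceptor, so a step in this assay toward weaker inhibition is expected, but of uncertain size; the estimated step is a 3.1-fold higher number from compound 3 to compound 4 (0.49 log units; beyond the scatter). Compound 4 is therefore expected at about 10000 nM, within a range from 1500 nM to 80000 nM.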

Compound 4, half-maximal inhibitory concentration: 40000 nM
Beside the measured number, compound 4's estimate is 4.0-fold (0.60 log units) below it; measured number inside the range.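

In this assay, fluoro in place of amino gives a 13-fold higher number from compound 3 to compound 4 (1.10 log units; beyond the scatter). This shows that the group on the aromatic carbon between two ring nitrogen atoms affects the read-out, whereas the earlier step, an at least 150-fold lower number from compound 1 to compound 3 (2.19 log units; beyond the scatter), concerned a different group. Compound 3 now has the lower number in both steps, so both its amino and its sulfanyl group go with stronger inhibition here, although nothing shown gives a measured cause for the new step.

From the compounds shown here alone, a single replacement cannot separate the loss of amino from the arrival of fluoro, so it remains open how a methylamino group, a hydroxyl group or a plain hydrogen at this position would read. Going by these compounds, it is also open whether the same step would appear with chloro in place of sulfanyl on the shared core.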